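Aryloxymethyl ketones: nitro added onto the fluorophenyl ether

The source may hold more compounds than are shown below. What is called first, only, known or untested is meant among the compounds shown, and "the series" means these compounds.

In a functional assay on Jurkat cells (Homo sapiens) (a lower number here means a stronger inhibitor, a higher number a weaker inhibitor), compound 1 `CC(C)[C@H](NC(=O)COc1cccc2ccccc12)C(=O)N[C@@H](CC(=O)O)C(=O)COc1ccccc1` gives 14000 nM.
Compound 2 `CC(C)[C@H](NC(=O)COc1cccc2ccccc12)C(=O)N[C@@H](CC(=O)O)C(=O)COc1ccc([N+](=O)[O-])cc1` reaches only the assay limit, > 100000 nM.
Compound 3 `CC(C)[C@H](NC(=O)COc1cccc2ccccc12)C(=O)N[C@@H](CC(=O)O)C(=O)COc1ccc(F)cc1` also stands at the assay limit, > 100000 nM.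

Compound 3 thus sits at the limit of > 100000 nM in this assay, at which 2 of the 3 values shown sit, with no number of its own; compound 1 alone carries a value. Compound 4 `CC(C)[C@H](NC(=O)COc1cccc2ccccc12)C(=O)N[C@@H](CC(=O)O)C(=O)COc1ccc([N+](=O)[O-])cc1F` differs from compound 3 by 2-fluoro-4-nitrophenyl in place of 4-fluorophenyl on an oxygen on a saturated carbon. For the measured compounds named here, two measured steps bear on this: an at least 7.1-fold higher number from compound 1 to compound 2 (0.85 log units; beyond the scatter) and an at least 7.1-fold higher number from compound 1 to compound 3 (0.85 log units; beyond the scatter), each substituent alone moving the number out of range. The step that the two limits leave unreadable from compound 2 to compound 3 adds nothing readable. With both groups present, no return below the limit is expected; the expected step is a step that the limit leaves unreadable from compound 3 to compound 4. Compound 4 is estimated at 200000 nM, range 50000 nM to 800000 nM.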

Compound 4, half-maximal inhibitory concentration: 30300 nM
Compound 4: the middle estimate sits 6.6-fold (0.82 log units) above what was measured; the measured number lies below the stated range.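

Both groups together bring the series back to a measurable number (an at least 3.3-fold lower number from compound 2 to compound 4 (0.51 log units; beyond the scatter)) and (an at least 3.3-fold lower number from compound 3 to compound 4 (0.51 log units; beyond the scatter)), though compound 1 remains ahead (a 2.2-fold higher number from compound 1 to compound 4 (0.34 log units; beyond the scatter)). Adding fluoro therefore reads in opposite directions, depending on whether nitro is present, so the two substituents do not simply add: the same change on two cores in this assay, an at least 7.1-fold higher number (0.85 log units; beyond the scatter) from compound 1 to compound 3 and an at least 3.3-fold lower number (0.51 log units; beyond the scatter) from compound 2 to compound 4, at least 23-fold (1.37 log units) apart, beyond the scatter of two such steps.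

The step between compound 2 and compound 3 cannot be read, as both values are limits. Still open, going by these compounds, is what a 2-fluorophenyl ether gives without nitro, and whether an amine or nitrile in place of nitro also keeps a measurable number.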